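This account rests on a few compounds, and the source may have more. Where it says the series, first, only, none or still open, it means among the compounds named here.

In an assay for inhibition of alkaline phosphatase, tissue-nonspecific isozyme (Homo sapiens), read by spectrophotometry, with stated times of 10 min and 20 min (on this read-out lower numbers stand for stronger inhibition and higher numbers for weaker inhibition), compound 1 `O=C1/C(=C/c2cccc(F)c2)NS(=O)(=O)c2ccccc21` gives 3190 nM. In this assay, for the measured compounds named here, compound 2 `O=C1/C(=C/c2ccc(F)cc2)NS(=O)(=O)c2ccccc21` gives 1350 nM, the lowest of the two numbers so far, and the single measured step is a 2.4-fold lower number from compound 1 to compound 2 (0.37 log units; beyond the scatter). Compound 3 `O=C1/C(=C/c2cccc(O)c2)NS(=O)(=O)c2ccccc21` differs from compound 2 by 3-hydroxyphenyl in place of 4-fluorophenyl on a double-bonded chain carbon bound to a double-bonded ring carbon. Going by the values given here, that measured step concerns only the two fluorophenyl groups; a hydroxyphenyl has no precedent, so the basis for any expectation is thin. For compound 3 a modest step toward a higher number is expected, a 1.9-fold higher number from compound 2 to compound 3 (0.27 log units; within the scatter), with wide uncertainty. Compound 3 is estimated at 2500 nM, within 800 nM to 8000 nM.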

Compound 3, half-maximal inhibitory concentration: 3570 nM
The estimate for compound 3 lay 1.4-fold (0.15 log units) below the measured number; the measured number falls inside the stated range.
By their numbers in this assay, from the lowest: compound 2; then compounds 1 and 3 (each within the scatter of the next).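

In this assay there is a 2.6-fold higher number from compound 2 to compound 3 (0.42 log units; beyond the scatter) with 3-hydroxyphenyl in place of 4-fluorophenyl on the double-bonded chain carbon. Hydroxy in place of fluoro on the aromatic carbon gives a 1.1-fold higher number from compound 1 to compound 3 (0.05 log units; within the scatter) and so no readable difference between 3-hydroxyphenyl and 3-fluorophenyl here, leaving compound 2 with the lowest number of the three. No evidence is available to explain these numbers.

Still open, from the compounds shown here alone, is how 4-hydroxyphenyl would compare with 4-fluorophenyl. Also open, going by these compounds, is how an amine, a methoxy group or a carboxylic acid would read on this aromatic ring.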